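The source may hold more compounds than are shown below. What is called first, only, known or untested is meant among the compounds shown, and "the series" means these compounds.

Measured compounds:
- compound 1 `CCCCCCCCCCCCCc1ccc(NC(=O)Nc2c(C(C)C)cccc2C(C)C)cc1` — 11 nM
- compound 2 `CC(C)c1cccc(C(C)C)c1NC(=O)Nc1ccccc1` — 910 nM
- compound 3 `Cc1ccc(NC(=O)Nc2c(C(C)C)cccc2C(C)C)cc1` — 250 nM

In an assay on isolated protein for inhibition of acyl-CoA:cholesterol acyltransferase (Oryctolagus cuniculus) (on this read-out lower numbers stand for stronger inhibition and higher numbers for weaker inhibition), compound 1 stands lowest of the three numbers. Compound 3 is nearest, and its value is well beyond the scatter of compound 1; compound 2 is furthest, also beyond the scatter. Within the data shown here, the one step within the set is a 3.6-fold lower number from compound 2 to compound 3 (0.56 log units; beyond the scatter), a modest change for a small group entering on the ring. Between compound 3 and compound 1 no single step is counted, but their two values show that the long chain in compound 1 goes with a much lower number than the methyl of compound 3.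

Compound 4 `CCCCCCCCCCc1ccc(NC(=O)Nc2c(C(C)C)cccc2C(C)C)cc1` is the unmeasured neighbour of compound 1. The change is hydrogen in place of propyl on a saturated chain carbon, ten or more bonds along the chain from an aromatic carbon. It shortens the chain but leaves most of it in place, so compound 4 sits between compound 3 and compound 1 in chain length, much nearer to compound 1. The values of compound 3 and compound 1 together suggest that each unit of chain carries only a small part of that gap; losing a propyl is therefore expected to cost little in this assay, a step of a 2.0-fold higher number from compound 1 to compound 4 (0.30 log units; within the scatter) that may barely exceed the scatter, in the direction of a higher number.

Compound 4 is expected to give 22 nM, with a plausible range from 8 nM to 60 nM.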

Compound 4, half-maximal inhibitory concentration: 13 nM
Compound 4: middle estimate off by 1.7-fold (0.23 log units), on the high side; the range from low to high includes it.
By their numbers in this assay, from the lowest: compounds 1 and 4 (each within the scatter of the next); then compound 3; then compound 2.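

Working notes on the series: in this assay, a 1.2-fold higher number from compound 1 to compound 4 (0.07 log units; within the scatter) shows that hydrogen in place of propyl on a saturated chain carbon, ten or more bonds along the chain from an aromatic carbon, gives no separation beyond the scatter. The decyl chain of compound 4 therefore keeps the large steps, with a 19-fold lower number from compound 3 to compound 4 (1.28 log units; beyond the scatter) for nonyl in place of hydrogen on a saturated chain carbon bound to an aromatic carbon, and a 70-fold lower number from compound 2 to compound 4 (1.85 log units; beyond the scatter) for the whole chain of compound 4, of which compound 2 carries none. The earlier compounds shown here showed only that the long chain of compound 1 went with a much lower number than the methyl of compound 3, whereas compound 4 shows that this chain can lose its outer propyl without a change beyond the scatter.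

Still open, going by these compounds, is how the number runs across intermediate lengths such as a butyl or hexyl chain, and whether a chain longer than that of compound 1, or one ending in an amine or a carboxylic acid, would fit the same picture. No supporting evidence bears on why the chain behaves this way in this series.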